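This account rests on a few compounds, and the source may have more. Where it says the series, first, only, none or still open, it means among the compounds named here.

Compound 1 `Nc1nc(NCCNc2ncc(-c3ncc[nH]3)c(-c3ccc(F)cc3F)n2)ccc1[N+](=O)[O-]`: > 0.5 h
Compound 2 `Nc1nc(NCCNc2ncc(-c3ncc[nH]3)c(-c3cc(F)c(F)cc3F)n2)ccc1[N+](=O)[O-]`: > 0.5 h

In an ADME assay on microsomes from liver (Rattus norvegicus) for metabolic stability (on this read-out lower numbers stand for a shorter-lived compound and higher numbers for a longer-lived compound), compound 1 gives > 0.5 h, which is a limit of the assay and not a number. Compound 2 gives > 0.5 h, which is likewise only a limit. Together they make up (the limit of > 0.5 h in this assay, at which 2 of the 2 values shown sit). Compound 3 `Nc1nc(NCCNc2ncc(-c3ncc[nH]3)c(-c3ccc(F)cc3Cl)n2)ccc1[N+](=O)[O-]` departs from compound 2 by 2-chloro-4-fluorophenyl in place of 2,4,5-trifluorophenyl on an aromatic carbon, with 2-chloro-4-fluorophenyl in place of 2,4,5-trifluorophenyl. Going by the values given here, one measured step bears on this change, a step that the two limits leave unreadable from compound 1 to compound 2, which also alters the substitution on the same aromatic ring. It offers neither a size nor a direction, so no step beyond the scatter is expected in this assay. The expected step is a step that the limit leaves unreadable from compound 2 to compound 3. For compound 3 the estimated half-life is 0.6 h, with an expected range from 0.3 h to 1.5 h.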

Compound 3, half-life: > 0.5 h
Compound 3: a limit, no number; the forecaster's own chance of this, stated with the estimate: 65%; the middle value is on the limit's open side.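

In this assay compound 3 gives > 0.5 h, which is a limit of the assay and not a number. No new step can be read from compound 1 or compound 2 to compound 3: the limit of > 0.5 h in this assay, at which 3 of the 3 values shown sit.

The compounds shown leave open how long the half-life of each actually is, and whether the changes on the aromatic ring shift it at all.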